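This account rests on a few compounds, and the source may have more. Where it says the series, first, only, none or still open, it means among the compounds named here.

For the measured compounds named here, in a physicochemical assay for solubility, read by chemiluminescence (on this read-out higher numbers stand for higher solubility and lower numbers for lower solubility), compound 1 (`O=C(CN(C(=O)c1ccc(N2CCCC2)cc1)C1CCCCC1)Nc1cc(F)cc(F)c1`) gives 5 ug/mL and compound 2 (`O=C(CN(C(=O)c1ccc(-c2ccccn2)cc1)C1CCCCC1)Nc1cc(F)cc(F)c1`) gives 6 ug/mL in a pair that lies within the scatter, so compound 2 stands level with the only other number known. Compound 3 (`O=C(CN(C(=O)c1ccc(-c2ccccn2)cc1)C1CCCOC1)Nc1cc(F)cc(F)c1`) carries oxan-3-yl in place of cyclohexyl on an amide-type nitrogen. Going by the values given here, the one measured step (a 1.2-fold higher number from compound 1 to compound 2 (0.08 log units; within the scatter)) sits on an aromatic carbon, elsewhere in the structure, and gives no direct measure of this change. Only a modest upward move in this assay is therefore expected (a 1.8-fold higher number from compound 2 to compound 3 (0.26 log units; within the scatter)). Compound 3 is estimated at 11 ug/mL with an expected range of 5 ug/mL to 28 ug/mL around it.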

Compound 3, solubility: 56 ug/mL
Beside the measured number, compound 3's estimate is 5.1-fold (0.71 log units) below it; the whole stated range lies below it.
By their numbers in this assay, from the lowest: compounds 1 and 2 (each within the scatter of the next); then compound 3.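

In this assay, the amide-type nitrogen turns out to be a position where one change moves the number well beyond the scatter: oxan-3-yl in place of cyclohexyl gives a 9.3-fold higher number from compound 2 to compound 3 (0.97 log units; beyond the scatter). The entering ring has the same heavy-atom count as cyclohexyl, differing by one oxygen and one hydrogen-bond acceptor. Nothing measured here accounts for this rise. On these data alone, it remains open whether oxan-4-yl, piperidin-3-yl or tetrahydrofuran-3-yl at this nitrogen would give a similar number. As far as these compounds go, it is also open whether oxan-3-yl would have the same effect with the pyrrolidin-1-yl group of compound 1 on the aromatic carbon.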